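This account rests on a few compounds, and the source may have more. Where it says the series, first, only, none or still open, it means among the compounds named here.

Measured so far:
Compound 1, `O=C(O)CCC(=O)N(C1CC1)C1c2ccccc2N(C(=O)OCc2ccccc2)C2CCC21`: 210 nM
Compound 2, `O=C(O)CCC(=O)N(C1CC1)[C@H]1c2ccccc2N(C(=O)c2ccc(OC(F)(F)F)cc2)[C@H]2CC[C@H]21`: 7 nM

In a functional assay on cells for antagonist activity at prostaglandin D2 receptor 2 (Homo sapiens), read by ELISA, chemiluminescence and cAMP accumulation, with stated times of 10 min and 60 min (a higher number here means a weaker inhibitor, a lower number a stronger inhibitor), compound 1 gives 210 nM. Compound 2 has the lowest of the two numbers: in this assay compound 2 gives 7 nM, and the gap to compound 1 lies well beyond the scatter of repeated measurements. For the measured compounds named here, no single-point step between the two measured compounds can be drawn, since they differ in more than one place, so the two values are simply reported as they stand.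

The next compound to be measured is compound 3, `O=C(O)CCC(=O)N(C1CC1)[C@H]1c2ccccc2N(C(=O)c2ccc(F)cc2)[C@H]2CC[C@H]21`. It keeps the core, the cyclopropyl amide and the acid chain of compound 2 and differs only at the aroyl group: fluoro in place of trifluoromethoxy on an aromatic carbon.

Going by the values given here, no measured pair isolates this change, so the expectation rests on the value of compound 2 alone. A modest weakening is expected, with the step from compound 2 to compound 3 estimated at a 2.9-fold higher number from compound 2 to compound 3 (0.46 log units; beyond the scatter). In this assay compound 3 is expected to give about 20 nM, within a range from 6 nM to 60 nM.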

Compound 3, half-maximal inhibitory concentration: 20 nM
Estimate against measurement, compound 3: no gap at the digits printed; the range from low to high includes it.
By their numbers in this assay, from the lowest: compound 2; then compound 3; then compound 1.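

In this assay, for the compounds shown here, a change on the aroyl group can now be read on its own for the first time, with the core, the cyclopropyl amide and the acid chain held fixed. Placing fluoro in place of trifluoromethoxy on the aromatic carbon gives a 2.9-fold higher number from compound 2 to compound 3 (0.46 log units; beyond the scatter), so this position responds measurably, although the step is modest even as the group shrinks from 5 heavy atoms to 1. Nothing measured for these compounds bears on why the step has this size.

This single pair cannot show how the number would respond to a chloro, methyl, methoxy, trifluoromethyl or nitrile group on the same carbon, or to a bare hydrogen there, so no order among such groups can yet be given. As far as these compounds go, the parts held fixed in this pair also remain untested by it, including how an ethyl or isopropyl group would compare with the cyclopropyl on the amide nitrogen, and how a longer chain or a tetrazole would compare with the present acid chain or its carboxylic acid.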